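This account rests on a few compounds, and the source may have more. Where it says the series, first, only, none or still open, it means among the compounds named here.

Compound 1, with the structure `O=S(=O)(NCCCNCc1ccc(Cl)cc1)c1cc(C(F)(F)F)cc(C(F)(F)F)c1`, was studied in a functional assay on ASPC1 cells (Homo sapiens) for inhibition, read by MTT assay, with a stated time of 72 h; on this read-out lower numbers stand for stronger inhibition of growth and higher numbers for weaker inhibition of growth. In this assay compound 1 gives 3000 nM. Its companion, compound 2, with the structure `O=S(=O)(NCCNCc1ccc(-c2ccccc2)cc1)c1cc(C(F)(F)F)cc(C(F)(F)F)c1`, gives 2800 nM in this assay. The two values lie within the scatter of one another, so on the numbers shown compound 1 cannot be told apart from compound 2; both sit at a modest level of growth inhibition, and neither can be called the more or the less active of the pair.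

From compound 1 the account moves to compound 3, with the structure `O=S(=O)(NCCCNCC1COc2ccccc2O1)c1cc(C(F)(F)F)cc(C(F)(F)F)c1`, which has not yet been measured in this assay. The change from compound 1 to compound 3 is 2,3-dihydro-1,4-benzodioxin-2-yl in place of 4-chlorophenyl on a saturated chain carbon bound to an amine nitrogen. Going by the values given here, no measured pair in the set shows this change or anything like it, so there is no step on which to lean. Among the compounds with values here, the pair of compound 1 and compound 2 shows only that a different group at this end of the chain left the number where it was. On that basis the step from compound 1 to compound 3 is expected to be a 1.2-fold higher number from compound 1 to compound 3 (0.07 log units; within the scatter), that is, no step beyond the scatter in either direction. Compound 3 is therefore estimated at 3500 nM in this assay, with a range from 1200 nM to 10000 nM.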

Compound 3, concentration for 50% growth inhibition: 2900 nM
The estimate for compound 3 lay 1.2-fold (0.08 log units) above the measured number; the measured number falls inside the stated range.
By their numbers in this assay, from the lowest: compounds 2, 3 and 1 (each within the scatter of the next).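

In this assay, going by these compounds alone, placing 2,3-dihydro-1,4-benzodioxin-2-yl in place of 4-chlorophenyl on a saturated chain carbon bound to an amine nitrogen gives a 1.0-fold lower number from compound 1 to compound 3 (0.01 log units; within the scatter), and this is the first step in the set in which only this one place differs. The exchange is not a small one on paper: the chlorine leaves, a six-membered non-aromatic ring with 2 hetero atoms enters, and 0 hydrogen-bond acceptors become 2, yet the two numbers remain within the scatter of each other, so this assay does not tell these two groups apart at this place. Nothing available bears on why the two groups read alike.

A single exchange at this place cannot show whether any other group there would move the number beyond the scatter, such as a pyridine ring, a carboxylic acid or a plain unsubstituted phenyl. Going by these compounds, it also remains open whether the same exchange would read alike on a longer chain, or with a nitrile in place of each trifluoromethyl group on the shared core.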